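Capping the secondary amine of compound 1 with methyl

A few compounds are considered here, and "the series" means these few. Any claim that something is new, unique, unknown or untested is made for them only; others in the source may bear on it.

Compound 1 `CN(C[C@H]1Cc2c(cccc2N2C[C@H]3CNC[C@H]3C2)CN1)[C@H]1CCCc2cccnc21` gives 10.3 nM in a functional assay on CCRF-CEM cells for antagonist activity at C-X-C chemokine receptor type 4 (Homo sapiens), read by calcium flux, with stated times of 25 min and 90 s (a higher number here means a weaker inhibitor, a lower number a stronger inhibitor), the lowest of the three numbers in hand. Compound 2 `CN(C)[C@@H]1CCN(c2cccc3c2C[C@H](CN(C)[C@H]2CCCc4cccnc42)NC3)C1` gives 10.4 nM and compound 3 `CN(C)C1CCN(c2cccc3c2C[C@H](CN(C)[C@H]2CCCc4cccnc42)NC3)CC1` gives 35.9 nM. Compound 4 `CN(C[C@H]1Cc2c(cccc2N2C[C@H]3CCN(C)[C@H]3C2)CN1)[C@H]1CCCc2cccnc21` carries a group of 9 heavy atoms (7 carbon, 2 nitrogen; 2 five-membered non-aromatic rings with 1 hetero atom each) in place of a group of 8 heavy atoms (6 carbon, 2 nitrogen; 2 five-membered non-aromatic rings with 1 hetero atom each), on an aromatic carbon, so the free amine hydrogen of the leaving group is replaced by methyl. Within the data shown here, no measured step is of exactly this kind; those at the same aromatic carbon are a 1.0-fold higher number from compound 1 to compound 2 (0.00 log units; within the scatter) and a 3.5-fold higher number from compound 1 to compound 3 (0.54 log units; beyond the scatter), with a 3.5-fold higher number from compound 2 to compound 3 (0.54 log units; beyond the scatter) between them. Compounds 2 and 3 both bear a dimethylamino there, and compound 2 sits within the scatter of compound 1. The step expected is a 1.5-fold higher number from compound 1 to compound 4 (0.16 log units; within the scatter), small, if anything toward a higher number. Compound 4 is estimated at 15 nM, range 6 nM to 40 nM.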

Compound 4, half-maximal inhibitory concentration: 18.7 nM
Beside the measured number, compound 4's estimate is 1.2-fold (0.10 log units) below it, and the stated range covers the measured number.
By their numbers in this assay, from the lowest: compounds 1, 2, 4 and 3 (each within the scatter of the next, the first and the last beyond it).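

In this assay the two-ring group with no hydrogen-bond donor stays within the scatter of the one carrying a donor, a 1.8-fold higher number from compound 1 to compound 4 (0.26 log units; within the scatter) being the step, so this aromatic carbon tolerates the loss of that amine hydrogen in a two-ring group as well. Compound 4 also lies within the scatter of both dimethylamino compounds, with a 1.8-fold higher number from compound 2 to compound 4 (0.25 log units; within the scatter) and a 1.9-fold lower number from compound 3 to compound 4 (0.28 log units; within the scatter) as its steps. No evidence bears on the reason for these small steps.

As far as these compounds go, whether that nitrogen accepts anything larger than methyl remains open. An acetyl, a longer chain such as butyl or a carboxylic acid there could show where tolerance ends.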